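The source may report more compounds than this note shows. Statements on the series, on what has been measured and on what is new or still open speak of the compounds shown alone.

compound 1 `CCCS(=O)(=O)Nc1ccc(F)c(C(=O)c2n[nH]c3ncc(-c4ccccc4)cc23)c1F` — 2.4%
compound 2 `CCCS(=O)(=O)Nc1ccc(F)c(C(=O)c2n[nH]c3ncc(-c4ccc([N+](=O)[O-])cc4)cc23)c1F` — 4.2%

In an assay for binding affinity to dual specificity mitogen-activated protein kinase kinase 4 (Homo sapiens), read by KINOMEscan, tested at 100 nM (on this read-out higher numbers stand for a weaker effect at the one concentration tested and lower numbers for a stronger effect), compound 1 gives 2.4% and compound 2 gives 4.2%; on these numbers compound 2 and compound 1 sit within the scatter of each other, so neither is set apart. Going by the values given here, the only measured step, a number 1.8 percentage points higher from compound 1 to compound 2 (within the scatter), also swaps a group at the same place and stayed within the scatter. Compound 3 `CCCS(=O)(=O)Nc1ccc(F)c(C(=O)c2n[nH]c3ncc(-c4ccc(S(N)(=O)=O)cc4Cl)cc23)c1F` differs from compound 2 by 2-chloro-4-sulfamoylphenyl in place of 4-nitrophenyl on an aromatic carbon, a larger change than the one measured, so no step beyond the scatter is expected, with some spread allowed. The expected step is a number 3.8 percentage points higher from compound 2 to compound 3 (within the scatter). Compound 3 is estimated at 8%, range 1% to 35%.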

Compound 3, a percentage reported as activity, at one concentration (the size of the read-out at that concentration, not a potency): 3.4%
The estimate for compound 3 lay 4.6 percentage points above the measured number, and the stated range covers the measured number.
By their numbers in this assay, from the lowest: compounds 1, 3 and 2 (each within the scatter of the next).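

In this assay, 2-chloro-4-sulfamoylphenyl at this position gives a number 0.8 percentage points lower from compound 2 to compound 3 (within the scatter) and a number 1 percentage points higher from compound 1 to compound 3 (within the scatter). The position therefore accepts a ring carrying both chlorine and a sulfamoyl group, with a hydrogen-bond donor absent from 4-nitrophenyl, without a step beyond the scatter. No evidence on hand bears on this result. On these data alone, the separate contributions of the chlorine and the sulfamoyl group remain open, as they enter together. Also open, as far as these compounds go, is whether an amine or a carboxylic acid on this phenyl ring would stay within the scatter.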